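Notes on the sulfur substituent of the shared core

This account rests on a few compounds, and the source may have more. Where it says the series, first, only, none or still open, it means among the compounds named here.

Measured compounds:
- compound 1, `CCCCCSc1nc(C(F)(F)F)ccc1CNC(=O)C(C)c1ccc(NS(C)(=O)=O)c(F)c1`, gives 2.5 nM in an assay on CHO-K1 cells for antagonist activity at transient receptor potential cation channel subfamily V member 1 (Homo sapiens), read by FLIPR; on this read-out lower numbers stand for stronger inhibition and higher numbers for weaker inhibition.
- compound 2, `CC1CCC(Sc2nc(C(F)(F)F)ccc2CNC(=O)C(C)c2ccc(NS(C)(=O)=O)c(F)c2)CC1`, gives 0.5 nM.

Within the data shown here, compound 1 stands highest of the two numbers known in this assay; its nearest neighbour is compound 2, reached by a 5.0-fold lower number from compound 1 to compound 2 (0.70 log units; beyond the scatter), a modest step that lies beyond the scatter.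

Compound 3, `COc1ccc(CSc2nc(C(F)(F)F)ccc2CNC(=O)C(C)c2ccc(NS(C)(=O)=O)c(F)c2)cc1`, has not yet been measured. It differs from compound 1 by 4-methoxyphenyl in place of butyl on a saturated chain carbon bound to a sulfur. Among the measured compounds shown here, the only step that bears on this is the one from compound 1 to compound 2, where a ring-bearing group also replaced the pentyl on the sulfur and gave a 5.0-fold lower number from compound 1 to compound 2 (0.70 log units; beyond the scatter). That single step is the whole basis here; the entering group in compound 3 is an aromatic ring carrying a methoxy rather than a saturated one, so the same size of step cannot be assumed. A lower number than compound 1 is expected, of a size that may remain within the scatter or reach a modest step. For compound 3 the expected value is 1.5 nM, within 0.5 nM to 5 nM, which means an expected step of a 1.7-fold lower number from compound 1 to compound 3 (0.22 log units; within the scatter).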

Compound 3, inhibition constant: 2.3 nM
For compound 3 the middle estimate is 1.5-fold (0.19 log units) below the measured one, within the range that was stated.
By their numbers in this assay, from the lowest: compound 2; then compounds 3 and 1 (each within the scatter of the next).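

In this assay, a ring in the group on the sulfur does not by itself go with a lower number: 4-methoxybenzyl in place of pentyl gives a 1.1-fold lower number from compound 1 to compound 3 (0.04 log units; within the scatter) and the two groups cannot be told apart here. The position still responds to the choice of ring-bearing group, as 4-methoxybenzyl in place of 4-methylcyclohexyl gives a 4.6-fold higher number from compound 2 to compound 3 (0.66 log units; beyond the scatter) and compound 2 alone stands apart from the other two by steps beyond the scatter. Nothing available accounts for this difference between the two ring-bearing groups.

The three compounds do not show whether the separation of compound 2 goes with its saturated ring, with the methyl on that ring, or with the absence of the methoxy, as these features change together between compound 2 and compound 3. Plain cyclohexyl, plain benzyl and 4-methylbenzyl on the sulfur would each separate part of this question, while an amine on the chain in place of the 4-methoxyphenyl would test a different kind of group at the same place.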